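A Furan Cap in Place of Trifluoromethylphenyl

This account rests on a few compounds, and the source may have more. Where it says the series, first, only, none or still open, it means among the compounds named here.

Of the compounds shown here, three sharing one core have been measured. Compound 1 `CCOC(=O)c1sc(-c2cccc(NC(=O)c3ccc(C(F)(F)F)cc3)c2)nc1Nc1ccc(N2CCN(C)CC2)cc1` gives 33% in a functional assay on Raji cells (Homo sapiens) for antiproliferative activity, read by CCK-8 assay, with a stated time of 72 h, tested at 40 uM; on this read-out lower numbers stand for less inhibition and higher numbers for more inhibition at the one concentration tested (going by the name of the read-out). Compound 2 `CCOC(=O)c1sc(-c2cccc(NC(=O)c3cccc(F)c3)c2)nc1Nc1ccc(N2CCN(C)CC2)cc1` gives 82.8% in this assay, and compound 3 `CN1CCN(c2ccc(Nc3nc(-c4cccc(NC(=O)c5ccc(C(F)(F)F)cc5)c4)sc3C(N)=O)cc2)CC1` gives 91.9% in this assay. Compound 3 thus shows the highest number of the three; its gap to compound 2 lies within the scatter, while compound 1 sits far below. Two single changes have been measured: a number 49.8 percentage points higher from compound 1 to compound 2 (beyond the scatter), and a number 58.9 percentage points higher from compound 1 to compound 3 (beyond the scatter).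

Compound 4 `CN1CCN(c2ccc(Nc3nc(-c4cccc(NC(=O)c5ccco5)c4)sc3C(N)=O)cc2)CC1` has not yet been measured. It differs from compound 3 by furan-2-yl in place of 4-(trifluoromethyl)phenyl on a carbonyl carbon. Going by the values given here, the one measured change that also removes 4-(trifluoromethyl)phenyl from the carbonyl carbon is a number 49.8 percentage points higher from compound 1 to compound 2 (beyond the scatter), a large rise. Among the compounds with values here, compound 3 already gives a high number, so little room remains upward, and the change to furan-2-yl has no direct precedent here. A small step, possibly slightly downward, is therefore expected, a number 6.9 percentage points lower from compound 3 to compound 4 (within the scatter). Compound 4 is estimated at 85%, within a range from 55% to 98%.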

Compound 4, a percentage reported as inhibition, at one concentration (the size of the read-out at that concentration, not a potency): 84.3%
Beside the measured number, compound 4's estimate is 0.7 percentage points above it, within the range that was stated.
By their numbers in this assay, from the lowest: compound 1; then compounds 2, 4 and 3 (each within the scatter of the next).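

With the amide kept, placing furan-2-yl in place of 4-(trifluoromethyl)phenyl on the carbonyl carbon gives a number 7.6 percentage points lower from compound 3 to compound 4 (within the scatter) in this assay. A five-membered aromatic ring with 1 hetero atom can therefore stand where a six-membered aromatic ring of carbon only stood, with no change beyond the scatter. Leaving 4-(trifluoromethyl)phenyl brought a large rise in the ethyl ester pair but not in this amide pair, although the entering groups differ, so the two steps are not a like-for-like comparison, and no measurement here offers an explanation for the difference.

On these data alone, whether a cap without an aromatic ring, such as a cyclohexyl ring or a short alkyl chain, would hold the number at this position remains open. So does the effect of furan-2-yl on the ethyl ester core.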